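Moving the Methyl Around the Amide Phenyl Ring

This account rests on a few compounds, and the source may have more. Where it says the series, first, only, none or still open, it means among the compounds named here.

Compound 1, `O=C(Nc1c(C(O)(C(F)(F)F)C(F)(F)F)ccc2ccccc12)C1CCC1`, in an assay on LtK cells with ATP-sensitive inward rectifier potassium channel 11 (Homo sapiens) as the target (a higher number here means that more compound is needed for the effect, a lower number that less compound is needed), gives 45 nM.
Compound 2, `Cc1ccccc1C(=O)Nc1c(C(O)(C(F)(F)F)C(F)(F)F)ccc2ccccc12`, gives 5550 nM.
Compound 3, `Cc1cccc(C(=O)Nc2c(C(O)(C(F)(F)F)C(F)(F)F)ccc3ccccc23)c1`, gives 23 nM.

Of the three numbers, compound 3 sits lowest, though its nearest neighbour is compound 1, and the gap there, a 2.0-fold lower number from compound 1 to compound 3 (0.29 log units; within the scatter), is within the scatter. Compound 2 stands far away on its own: a 120-fold higher number from compound 1 to compound 2 (2.09 log units; beyond the scatter), and a 240-fold lower number from compound 2 to compound 3 (2.38 log units; beyond the scatter).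

Compound 4 is `Cc1ccc(C(=O)Nc2c(C(O)(C(F)(F)F)C(F)(F)F)ccc3ccccc23)cc1`. It differs from compound 3 in one place: 4-methylphenyl in place of 3-methylphenyl on a carbonyl carbon

Within the data shown here, the steps that bear on it are those among the three methylphenyl and cyclobutyl amides. Moving the methyl from the 2-methylphenyl of compound 2 to the 3-methylphenyl of compound 3 produced a large step, whereas the exchange of cyclobutyl for 3-methylphenyl changed little. Among the measured compounds shown here, no measured pair tells directly how 3-methylphenyl compares with 4-methylphenyl, so the expectation rests on compound 3 alone: a small step in either direction, or none beyond the scatter. For compound 4 the expected value in this assay is 30 nM, with a range from 8 nM to 120 nM, which means an expected step of a 1.3-fold higher number from compound 3 to compound 4 (0.12 log units; within the scatter).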

Compound 4, half-maximal effective concentration: 76 nM
Estimate against measurement, compound 4: 2.5-fold (0.40 log units) below; measured number inside the range.
By their numbers in this assay, from the lowest: compounds 3, 1 and 4 (each within the scatter of the next, the first and the last beyond it); then compound 2.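

In this assay, among these compounds, the move of the methyl from 3-methylphenyl to 4-methylphenyl has a measurable cost of its own (a 3.3-fold higher number from compound 3 to compound 4 (0.52 log units; beyond the scatter)), a modest step that no earlier pair could show. The 2-methylphenyl amide remains the outlier among the three methylphenyl amides, as the large step to the 4-methylphenyl amide confirms (a 73-fold lower number from compound 2 to compound 4 (1.86 log units; beyond the scatter)), so two of the three methyl placements on this ring stay close to the cyclobutyl amide, and one does not. The 4-methylphenyl group also cannot be told apart from cyclobutyl on the carbonyl carbon (a 1.7-fold higher number from compound 1 to compound 4 (0.23 log units; within the scatter)), just as 3-methylphenyl could not, even though the two methylphenyl isomers differ from each other beyond the scatter.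

Nothing measured here explains why the methyl position matters so unevenly. From the compounds shown here alone, it also remains open whether a chlorine atom, a methoxy group or an ethyl chain in place of the methyl would show the same order across the three ring placements.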